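Swapping Chlorine for Fluorine on Two Aromatic Rings

The compounds below may be only part of what the source reports. "The series", "measured", "known", "first", "only" and "open" are said of these compounds alone.

Compound 1 `Nc1ccccc1NC(=O)c1ccc(NC(=S)NCc2cccc(F)c2)cc1` and compound 2 `Nc1ccccc1NC(=O)c1ccc(NC(=S)NCc2cccc(Cl)c2)cc1` share one core and differ in a single halogen. In a functional assay on HCT-116 cells (Homo sapiens) for cytotoxicity, read by MTT assay, with a stated time of 72 h (a higher number here means a weaker inhibitor, a lower number a stronger inhibitor), compound 1 gives 5900 nM, and compound 2 gives 5900 nM. The change between them is fluoro in place of chloro on an aromatic carbon, and it made no change at the digits printed from compound 2 to compound 1 (within the scatter). Compound 3 `Nc1ccccc1NC(=O)c1ccc(NC(=O)NCc2ccc(Cl)nc2)cc1` carries a different core; the difference between the two cores is not broken down here. In this assay compound 3 gives 5200 nM. Compound 4 `Nc1ccccc1NC(=O)c1ccc(NC(=O)NCc2ccc(F)nc2)cc1` differs from compound 3 by fluoro in place of chloro on an aromatic carbon. Here the ring holds one nitrogen and the position is next to the ring nitrogen, para to a large group, whereas in compound 1 the ring is of carbon only and the position is meta to a large group, so this is the same kind of change, not the same. Because the earlier swap made no change at the digits printed from compound 2 to compound 1 (within the scatter), the step of a 1.1-fold higher number from compound 3 to compound 4 (0.02 log units; within the scatter) is expected to be small. Compound 4 is estimated at 5500 nM, between 2500 nM and 12000 nM.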

Compound 4, half-maximal inhibitory concentration: 14000 nM
Estimate against measurement, compound 4: 2.5-fold (0.41 log units) below; the whole stated range lies below it.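

In this assay, the swap from 6-chloropyridin-3-yl to 6-fluoropyridin-3-yl gives a 2.7-fold higher number from compound 3 to compound 4 (0.43 log units; beyond the scatter), so a change that left the numbers of the first pair unmoved weakens the compound on this core. The same kind of swap therefore did not carry over unchanged from one core to the other: the same change on two cores in this assay, no change at the digits printed (within the scatter) from compound 2 to compound 1 and a 2.7-fold higher number (0.43 log units; beyond the scatter) from compound 3 to compound 4, 2.7-fold (0.43 log units) apart, beyond the scatter of two such steps. Going by these compounds alone, with only one pair on each core, and the halogen on a different ring and at a different place in each pair, this does not show which structural difference is responsible or why the two steps differ.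

As far as these compounds go, it remains open how a methyl group or a nitrile in place of the chloro of compound 3 would compare. From the compounds shown here alone, it is also open whether the fluoro step would recur on other rings or cores.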